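This account rests on a few compounds, and the source may have more. Where it says the series, first, only, none or still open, it means among the compounds named here.

Compound 2 `CCCCc1nc(N2CCN(C(=O)COc3ccc(Cl)cc3)CC2)c2cc(F)sc2n1` stands lowest of the two numbers measured in a functional assay on cells (Lymphocyte) (on this read-out lower numbers stand for stronger inhibition and higher numbers for weaker inhibition), where compound 2 gives 1330 nM. Within the data shown here, its only neighbour, compound 1 `O=C(COc1ccc(Cl)cc1)N1CCN(c2ncnc3sc(F)cc23)CC1`, gives 6350 nM in this assay. Among the measured compounds shown here, the single measured step, a 4.8-fold lower number from compound 1 to compound 2 (0.68 log units; beyond the scatter), is butyl in place of hydrogen on an aromatic carbon, and it bears directly on the question at hand. Compound 3 `Cc1nc(N2CCN(C(=O)COc3ccc(Cl)cc3)CC2)c2cc(F)sc2n1` differs from compound 2 by hydrogen in place of propyl on a saturated chain carbon bound to an aromatic carbon. This removes most of the chain that arrived in the step from compound 1 to compound 2 while leaving a methyl in its place, so a number lying between those of compound 1 and compound 2 is expected rather than a full return. The step is expected as a 2.3-fold higher number from compound 2 to compound 3 (0.35 log units; beyond the scatter), a rise of moderate size. For compound 3 the estimate in this assay is 3000 nM, with a range from 1300 nM to 7000 nM.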

Compound 3, half-maximal inhibitory concentration: 3390 nM
Beside the measured number, compound 3's estimate is 1.1-fold (0.05 log units) below it, within the range that was stated.
By their numbers in this assay, from the lowest: compound 2; then compounds 3 and 1 (each within the scatter of the next).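

In this assay, the change from butyl to methyl gives a 2.5-fold higher number from compound 2 to compound 3 (0.41 log units; beyond the scatter) and so gives back part of what the butyl chain brought to this position. Set against hydrogen on the same aromatic carbon, methyl gives a 1.9-fold lower number from compound 1 to compound 3 (0.27 log units; within the scatter) and stays within the scatter, so among these three compounds only butyl stands clearly apart from hydrogen, and a single carbon at this place is not enough to separate the two. Nothing measured here explains this difference between the chains.

From the compounds shown here alone, whether ethyl or propyl already matches butyl, and whether a longer chain such as hexyl lowers the number further, remains open. So does what a branched group such as tert-butyl, or an amine at the end of the chain, would do at this position.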